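Removing the ester from a weak thiophene-type compound

This account rests on a few compounds, and the source may have more. Where it says the series, first, only, none or still open, it means among the compounds named here.

Compound 1 `CCOC(=O)c1cc(-c2ccc(OC)cc2)c(-c2cc(OC)c(OC)c(OC)c2)s1`: 7630 nM
Compound 2 `CCOC(=O)c1cc(-c2ccc(OC)c(O)c2)c(-c2cc(OC)c(OC)c(OC)c2)s1`: 82600 nM

Both values come from a functional assay on HT-1080 cells (Homo sapiens) for antiproliferative activity, read by MTT assay, with a stated time of 72 h; a higher number here means a weaker inhibitor, a lower number a stronger inhibitor. Of the two, compound 2 has the higher number, which marks the weaker inhibitor. Among the compounds with values here, the only measured step is an 11-fold higher number from compound 1 to compound 2 (1.03 log units; beyond the scatter), made by putting hydroxy in place of hydrogen on an aromatic carbon.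

Compound 3 `COc1ccc(-c2ccsc2-c2cc(OC)c(OC)c(OC)c2)cc1O` keeps that hydroxy and changes another place: hydrogen in place of ethoxycarbonyl on an aromatic carbon. Put simply, this is hydrogen in place of ethoxycarbonyl on an aromatic carbon.

Within the data shown here, no measured step touches the ethoxycarbonyl, so the data give no direct guide. Among the measured compounds shown here, the one measured step bears on it only indirectly, by showing that a single change can move the number in this assay a long way. For the measured compounds named here, compound 2, at 82600 nM, sits at the top of the numbers so far, and a whole group leaves, so a large step downward is expected, though with little certainty. The expected change is a 28-fold lower number from compound 2 to compound 3 (1.44 log units; beyond the scatter). For compound 3 the estimate is 3000 nM, with an estimated range of 40 nM to 60000 nM.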

Compound 3, half-maximal inhibitory concentration: 2120 nM
For compound 3 the middle estimate is 1.4-fold (0.15 log units) above the measured one; measured number inside the range.
By their numbers in this assay, from the lowest: compound 3; then compound 1; then compound 2.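

In this assay, replacing the ethoxycarbonyl next to the ring sulfur with a bare hydrogen gives a 39-fold lower number from compound 2 to compound 3 (1.59 log units; beyond the scatter), so this place on the five-membered ring can move the number a long way, and the ester group is not needed for compound 3 to register activity. The step also runs in the opposite direction to the only earlier one, an 11-fold higher number from compound 1 to compound 2 (1.03 log units; beyond the scatter): adding the hydroxy raised the number, whereas taking away the ester, a group of five heavy atoms, lowered it. What lies behind this drop remains unexplained, as no supporting measurement on the cause is available here.

From the compounds shown here alone, it remains open whether removing the ester would have a similar effect on compound 1, which has no hydroxy, so the two changes cannot yet be treated as independent of each other. The compounds shown carry only ethoxycarbonyl or hydrogen at this place, so it is also unknown whether the smaller number belongs to hydrogen alone or would persist with a methyl, a carboxylic acid or an amide there.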